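Estimating compound 3 from a single measured step

The source may report more compounds than this note shows. Statements on the series, on what has been measured and on what is new or still open speak of the compounds shown alone.

Measured in a physicochemical assay for lipophilicity, measured as octanol-water partition, at pH 7.4; a higher number here means a more lipophilic compound, a lower number a more polar compound:
- Compound 1 `O=C([C@H](O)CS(=O)(=O)c1ccc2cc(Cl)ccc2c1)N1CCC(n2cc[nH]c2=O)CC1`: 1.79
- Compound 2 `O=C([C@H](O)CS(=O)(=O)c1ccc2cc(Cl)ccc2c1)N1CCC(N2CCCC2=O)CC1`: 1.96

Compound 2, at 1.96, lies within the usual scatter of compound 1, so these numbers do not separate the two. Compound 3 `O=C([C@H](O)CS(=O)(=O)c1ccc2cc(Cl)ccc2c1)N1CCC(N2CCCOC2=O)CC1` keeps the rest of compound 2 and changes one group: a group of 7 heavy atoms (4 carbon, 1 nitrogen, 2 oxygen; one six-membered non-aromatic ring with 2 hetero atoms) in place of a group of 6 heavy atoms (4 carbon, 1 nitrogen, 1 oxygen; one five-membered non-aromatic ring with 1 hetero atom), on a saturated ring carbon. The 2-oxopyrrolidin-1-yl group leaves, and a group with one six-membered non-aromatic ring with 2 hetero atoms takes its place on the same saturated ring carbon. Among the compounds with values here, only one measured step bears on this: a number 0.17 log units higher from compound 1 to compound 2 (within the scatter). It also swaps the group on that carbon, although with a different pair of groups, so it is a weak guide. On that single small step, no change beyond the scatter is expected in this assay. The expected step is a number 0.06 log units lower from compound 2 to compound 3 (within the scatter). For compound 3 the estimate is 1.9, with an expected range from 1.5 to 2.3.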

Compound 3, distribution coefficient: 1.67
Estimate against measurement, compound 3: 0.23 log units above; low and high end bracket the measured number.
By their numbers in this assay, from the lowest: compounds 3, 1 and 2 (each within the scatter of the next).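

In this assay the group on this saturated ring carbon was changed again, giving a number 0.29 log units lower from compound 2 to compound 3 (within the scatter) and, against the aromatic ring group, a number 0.12 log units lower from compound 1 to compound 3 (within the scatter) as the second reading. The larger ring with its second ring oxygen therefore joins the other two ring groups, and the three compounds cannot be put in any order by these numbers, so at this position these three groups are interchangeable for this read-out. Nothing shown explains why these steps stay so small.

Going by these compounds, all three groups are rings with a carbonyl and no net charge, so what an amine or a carboxylic acid on this carbon would do to the number remains open. On these data alone, whether the same small steps would hold with a different shared core also remains open.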